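The compounds below may be only part of what the source reports. "The series", "measured", "known", "first", "only" and "open" are said of these compounds alone.

Compound 2 `Cc1noc(-c2ccccc2NCC2=NCCN2)n1` is known in a functional assay for activation of Alpha-1B adrenergic receptor (Homo sapiens), read by calcium flux (a higher number here means that more compound is needed for the effect, a lower number that less compound is needed), only by a limit: in that test compound 2 gives < 5020 nM. Compound 1 `c1ccc(-c2cnoc2)c(NCC2=NCCN2)c1` likewise sits at a limit, giving < 100000 nM in this assay. The step that the two limits leave unreadable from compound 1 to compound 2 therefore cannot be read, and it involves a different change anyway. Compound 3 `CC/C(=N/OC)c1ccccc1NCC1=NCCN1` changes compound 2 by a group of 6 heavy atoms (4 carbon, 1 nitrogen, 1 oxygen; no ring) in place of a group of 6 heavy atoms (3 carbon, 2 nitrogen, 1 oxygen; one five-membered aromatic ring with 3 hetero atoms), on an aromatic carbon. For the measured compounds named here, no measured step covers this change, so only a rough expectation is possible. Compound 3 is expected to give 1500 nM, within 150 nM to 15000 nM. This estimate means a step that the limit leaves unreadable from compound 2 to compound 3, which is expected to stay within the scatter.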

Compound 3, half-maximal effective concentration: < 5020 nM
Compound 3 gave a limit, no number (the forecaster's own chance of this, stated with the estimate: 30%); the middle value lies beyond the limit too.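

For the compounds shown here, compound 1, compound 2 and compound 3 are each known in this assay only as limits, so no step between them can be read. Still open, as far as these compounds go, is how much of each compound the effect actually needs, and whether any of these group changes alters that amount.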